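The compounds below may be only part of what the source reports. "The series", "measured", "known", "first", "only" and "open" are said of these compounds alone.

Of the compounds shown here, two sharing one core have so far been tested in an assay on HeLa cells with Bile acid receptor (Homo sapiens) as the target, read by a luciferase reporter, with a stated time of 24 h; on this read-out lower numbers stand for an effect already at smaller amounts and higher numbers for an effect only at larger amounts of compound. Compound 1 `CC(C)(C)c1ccc(C(=O)NCc2ccc(C(=O)O)cc2F)cc1` gives 7.8 nM in this assay. Compound 2 `C[S+]([O-])c1ccc(CNC(=O)c2ccc(C(C)(C)C)cc2)cc1` gives 1300 nM in this assay, the highest number of the two, and its gap to compound 1 lies well beyond the usual scatter. Compound 3 `CC(C)(C)c1ccc(C(=O)NCc2ccc(OCC(=O)O)cc2)cc1` has not yet been measured. It differs from compound 2 in one place: a group of 5 heavy atoms (2 carbon, 3 oxygen; no ring) in place of a group of 3 heavy atoms (1 carbon, 1 oxygen, 1 sulfur; no ring), on an aromatic carbon. The change sits on an aromatic carbon of a six-membered aromatic ring of carbon only, para to a large group, and the entering carboxymethoxy ends in the same kind of acid that compound 1 carries. Given that compound 1 gives 7.8 nM while compound 2 gives 1300 nM, the expected step is a 43-fold lower number from compound 2 to compound 3 (1.64 log units; beyond the scatter), a clear drop in the number. Compound 3 is therefore expected to give about 30 nM in this assay, with a plausible range from 5 nM to 200 nM.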

Compound 3, half-maximal effective concentration: 730 nM
The estimate for compound 3 lay 24-fold (1.39 log units) below the measured number; the measured number lies above the stated range.
By their numbers in this assay, from the lowest: compound 1; then compounds 3 and 2 (each within the scatter of the next).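

In this assay, placing carboxymethoxy on this aromatic carbon, para to a large group, in place of the sulfur-containing group of compound 2 gives a 1.8-fold lower number from compound 2 to compound 3 (0.25 log units; within the scatter). At this position, then, the two groups cannot be told apart in this assay, even though they differ in size and the entering group ends in a carboxylic acid, so an acid at the end of this group is not enough on its own to separate compound 3 from compound 2. No measurement shown here explains why the exchange leaves the number within the usual scatter.

Still open, on these data alone, is whether the link between the ring and the acid matters, as a carboxymethyl group without the ether oxygen or a longer carboxypropoxy chain could show. Also open, as far as these compounds go, is how a tetrazole at this position would read in this assay.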